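The compounds below may be only part of what the source reports. "The series", "measured", "known", "first", "only" and "open" are said of these compounds alone.

Measured compounds:
- compound 1 `COc1cc2c(Oc3ccc(NC(=O)c4nn(-c5ccc(Br)cc5)c(=O)c5ccccc45)cc3F)ccnc2cc1OCCCN1CCCC1`: 230 nM
- compound 2 `COc1ccc(-n2nc(C(=O)Nc3ccc(Oc4ccnc5cc(OCCCN6CCCC6)c(OC)cc45)c(F)c3)c3ccccc3c2=O)cc1`: 1320 nM

Among the compounds with values here, in a functional assay on MKN-45 cells (Homo sapiens) for cytotoxicity, read by MTT assay, with a stated time of 72 h (on this read-out higher numbers stand for weaker inhibition and lower numbers for stronger inhibition), compound 1 stands lowest of the two numbers; the only other measured compound is compound 2, and the sole measured step, a 5.7-fold higher number from compound 1 to compound 2 (0.76 log units; beyond the scatter), concerns methoxy in place of bromo on an aromatic carbon. Within the data shown here, nothing measured so far touches the basic amine at the end of the alkoxy chain.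

Compound 3 `COc1cc2c(Oc3ccc(NC(=O)c4nn(-c5ccc(Br)cc5)c(=O)c5ccccc45)cc3F)ccnc2cc1OCCCN1CCCCC1` is not yet measured. It differs from compound 1 by piperidin-1-yl in place of pyrrolidin-1-yl on a saturated chain carbon, three bonds along the chain from an oxygen on an aromatic ring. Among the measured compounds shown here, the bromo-bearing ring of compound 1 is kept unchanged, so the one measured step does not bear on this change. For the measured compounds named here, no measured pair shows what ring expansion at this chain terminus does in this assay, so there is no basis for expecting a step beyond the scatter in either direction.

Compound 3 is therefore expected near 230 nM, within a range of 100 nM to 550 nM. The expected step is no change at the digits printed from compound 1 to compound 3 (within the scatter), which is within the scatter of repeated measurements.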

Compound 3, half-maximal inhibitory concentration: 500 nM
Beside the measured number, compound 3's estimate is 2.2-fold (0.34 log units) below it; the range from low to high includes it.
By their numbers in this assay, from the lowest: compound 1; then compound 3; then compound 2.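

Within the data shown here, the 3-(pyrrolidin-1-yl)propyl end of the chain is the first site where a change at the basic end has been read, and it is not silent. In this assay, piperidin-1-yl in place of pyrrolidin-1-yl gives a 2.2-fold higher number from compound 1 to compound 3 (0.34 log units; beyond the scatter), a modest step, so the five-membered ring is preferred over the six-membered ring at this position, at least with the bromo-bearing ring kept. No measurement at hand accounts for this step, and the cytotoxicity numbers alone do not tie it to any property of either ring.

The compounds shown leave open whether the step follows ring size or something specific to these two rings, which a morpholin-4-yl or dimethylamino end on the same propyl chain, or a shorter ethyl or longer butyl linker carrying pyrrolidin-1-yl, would help to separate. They also leave open whether the piperidin-1-yl change gives a similar step when methoxy stands in place of bromo, as the two changes have not been read together on one compound.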